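The compounds below may be only part of what the source reports. "The series", "measured", "known", "first", "only" and "open" are said of these compounds alone.

Measured so far in a functional assay on BGC-823 cells (Homo sapiens) for antiproliferative activity, read by MTT assay, tested at 5 uM; a lower number here means a weaker effect, a higher number a stronger effect of the compound at the concentration tested:
compound 1, `COc1cc(C2=NN(C(C)=O)C(c3cccc(OC)c3OC)O2)cc(OC)c1OC`, gives 17.5%;
compound 2, `COc1cc(C2=NN(C(C)=O)C(c3ccccc3C(F)(F)F)O2)cc(OC)c1OC`, gives 34.8%;
compound 3, `COc1cc(C2=NN(C(C)=O)C(c3ccc(F)cc3)O2)cc(OC)c1OC`, gives 13.3%.

Compound 3 holds the lowest of the three numbers. Against compound 1 the gap is a number 4.2 percentage points lower from compound 1 to compound 3 (within the scatter), so the two cannot be separated; against compound 2 the gap is a number 21.5 percentage points lower from compound 2 to compound 3 (beyond the scatter), a modest but real drop.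

Compound 4, `COc1cc(C2=NN(C(C)=O)C(c3ccccc3F)O2)cc(OC)c1OC`, differs from compound 3 in one place: 2-fluorophenyl in place of 4-fluorophenyl on a saturated ring carbon.

Among the compounds with values here, two measured steps bear on this. The step of a number 21.5 percentage points lower from compound 2 to compound 3 (beyond the scatter) shows that a 2-(trifluoromethyl)phenyl on the saturated ring carbon sits clearly above the 4-fluorophenyl. On the other hand, the step of a number 17.3 percentage points higher from compound 1 to compound 2 (beyond the scatter) shows that a 2,3-dimethoxyphenyl, which also carries substituents toward the ring junction, sits well below the 2-(trifluoromethyl)phenyl and level with the 4-fluorophenyl. Within the data shown here, a 2-fluorophenyl has no direct precedent here, so the expected step of a number 8.7 percentage points higher from compound 3 to compound 4 (within the scatter) is taken as small and upward, not certainly beyond the scatter. Compound 4 is therefore estimated at 22%, within a range of 8% to 40%.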

Compound 4, a percentage reported as inhibition, at one concentration (the size of the read-out at that concentration, not a potency): 32.8%
Compound 4: the middle estimate sits 10.8 percentage points below what was measured, within the range that was stated.
By their numbers in this assay, from the lowest: compounds 3 and 1 (each within the scatter of the next); then compounds 4 and 2 (each within the scatter of the next).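

In this assay the same atoms give a number 19.5 percentage points higher from compound 3 to compound 4 (beyond the scatter) when 2-fluorophenyl replaces 4-fluorophenyl, so at this saturated ring carbon the level follows where the fluoro sits on the phenyl and not merely its presence. Fluoro in place of trifluoromethyl gives a number 2 percentage points lower from compound 2 to compound 4 (within the scatter) and leaves the two compounds inseparable, which shows that 2-(trifluoromethyl)phenyl is not alone in reaching this level. The step of a number 15.3 percentage points higher from compound 1 to compound 4 (beyond the scatter) sets 2-fluorophenyl above 2,3-dimethoxyphenyl, and compound 1 goes against any reading in which a group at that place on the phenyl is enough to raise the number.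

Nothing at hand accounts for these steps. Still open, from the compounds shown here alone, is whether a chlorine or an amine in place of the fluoro of 2-fluorophenyl would hold the level of compound 4.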